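Urea tail variation on the shared core

The source may hold more compounds than are shown below. What is called first, only, known or untested is meant among the compounds shown, and "the series" means these compounds.

Compound 2 `CN(C)CCCN(C)C(=O)Nc1cc2c(Nc3ccc(F)c(Cl)c3)ncnc2cc1O[C@H]1CCOC1` gives 200 nM in a functional assay on A-431 cells (Homo sapiens) for antiproliferative activity, read by sulforhodamine B assay, with a stated time of 72 h; on this read-out lower numbers stand for stronger inhibition and higher numbers for weaker inhibition; among the two measured numbers it is the lowest, but compound 1 `O=C(NCCN1CCCC1)Nc1cc2c(Nc3ccc(F)c(Cl)c3)ncnc2cc1O[C@H]1CCOC1` with 247 nM sits within the scatter of it, so no order between the two is claimed. Going by the values given here, the one measured step, a 1.2-fold lower number from compound 1 to compound 2 (0.09 log units; within the scatter), is an exchange of the amine-bearing tail on the carbonyl carbon and produced no movement beyond the scatter. Compound 3 `O=C(Nc1cc2c(Nc3ccc(F)c(Cl)c3)ncnc2cc1O[C@H]1CCOC1)N1CCC(N2CCCC2)CC1` differs from compound 2 by 4-(pyrrolidin-1-yl)piperidin-1-yl in place of (3-(dimethylamino)propyl)(methyl)amino on a carbonyl carbon. Among the compounds with values here, this is again an exchange of the tail on the carbonyl carbon, and the only step that bears on it, a 1.2-fold lower number from compound 1 to compound 2 (0.09 log units; within the scatter), stayed within the scatter. A move of similar size, or none beyond the scatter, is therefore expected, estimated as a 1.2-fold higher number from compound 2 to compound 3 (0.06 log units; within the scatter). Compound 3 is expected at 230 nM, with a range from 80 nM to 700 nM.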

Compound 3, half-maximal inhibitory concentration: 317 nM
Beside the measured number, compound 3's estimate is 1.4-fold (0.14 log units) below it; the range from low to high includes it.
By their numbers in this assay, from the lowest: compounds 2, 1 and 3 (each within the scatter of the next).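

In this assay the tail on the carbonyl carbon now includes a form with two non-aromatic rings, 4-(pyrrolidin-1-yl)piperidin-1-yl, and the exchange gives a 1.6-fold higher number from compound 2 to compound 3 (0.20 log units; within the scatter); against the open-chain tail of compound 1 it gives a 1.3-fold higher number from compound 1 to compound 3 (0.11 log units; within the scatter). Going by these compounds alone, this read-out therefore does not separate the ring-free (3-(dimethylamino)propyl)(methyl)amino tail from this two-ring tail, so at this position the series so far extends from open chains to a two-ring tail with no change beyond the scatter. Nothing at hand explains why these tails read alike.

Open, going by these compounds, is whether this holds for a tail with no amine, such as a plain butyl chain, or one ending in a carboxylic acid. Also open, on these data alone, is whether these tails would read alike on a core other than the shared one.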